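Methylating the Amine Nitrogen of Compound 3

This account rests on a few compounds, and the source may have more. Where it says the series, first, only, none or still open, it means among the compounds named here.

Three compounds have been measured in a functional assay on cells for agonist activity at Glucose-dependent insulinotropic receptor (Homo sapiens), read by a luciferase reporter, with a stated time of 4 h; a lower number here means a smaller maximal response, a higher number a larger maximal response:
Compound 1 `CCc1cnc(N2CCC(c3coc4c(N5CCc6cc(S(C)(=O)=O)ccc65)ncnc34)CC2)nc1` gives 154%.
Compound 2 `CC(=O)c1cnc(N2CCC(c3coc4c(N5CCc6cc(S(C)(=O)=O)ccc65)ncnc34)CC2)nc1` gives 12%.
Compound 3 `CC(C)(C)OC(=O)N1CCC(c2coc3c(Nc4ccc(S(C)(=O)=O)cc4F)ncnc23)CC1` gives 123%.

Compound 3 stands second highest of these three numbers. Its nearest neighbour is compound 1, whose number is higher by more than the usual scatter; compound 2 lies much lower, also beyond the scatter. Compound 4 `CN(c1ccc(S(C)(=O)=O)cc1F)c1ncnc2c(C3CCN(C(=O)OC(C)(C)C)CC3)coc12` is the next compound to be measured in this assay. It differs from compound 3 in one place: methyl in place of hydrogen on a nitrogen on an aromatic ring.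

For the measured compounds named here, the one measured step, a number 142 percentage points lower from compound 1 to compound 2 (beyond the scatter), concerns an aromatic carbon, not the nitrogen changed here, and so says little about what a methyl on that nitrogen will do. Going by the values given here, no measured pair shows a methyl in place of hydrogen on a nitrogen on an aromatic ring. The step of a number 28 percentage points lower from compound 3 to compound 4 (beyond the scatter) is therefore estimated with little support, and its direction is open. Compound 4 is expected to give about 95%, within a range from 30% to 150%.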

Compound 4, largest response reached (Emax), in percent of the reference or control that the assay uses: 6%
Compound 4: middle estimate off by 89 percentage points, on the high side; measured number outside the range, below it.
By their numbers in this assay, from the lowest: compounds 4 and 2 (each within the scatter of the next); then compound 3; then compound 1.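

Putting methyl in place of hydrogen on this nitrogen gives a number 117 percentage points lower from compound 3 to compound 4 (beyond the scatter) in this assay. For the compounds shown here, the only earlier step concerned an aromatic carbon, so this is the first measured sign that the nitrogen is sensitive to change: adding a single heavy atom there takes away most of the response that compound 3 gives. The data shown offer no explanation for this drop.

As far as these compounds go, it remains open whether the loss is specific to methyl or would also follow from other groups on this nitrogen, such as an ethyl, an acetyl or a longer chain. From the compounds shown here alone, it is equally open whether the same methyl would cost as much response in a compound that carries different groups elsewhere on the molecule.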